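Benzyl for Cyclohexyl on the Imidazole Nitrogen of Compound 2

The source may report more compounds than this note shows. Statements on the series, on what has been measured and on what is new or still open speak of the compounds shown alone.

Measured compounds:
Compound 1, `O=Cc1ccc(-c2cn3ccnc3c(-c3ccc4ncn(C5CCCCC5)c4c3)n2)cc1`: 13%
Compound 2, `c1cn2cc(-c3ccc4c(c3)ncn4C3CCCCC3)nc(-c3ccc4ncn(C5CCCCC5)c4c3)c2n1`: 7.38%

Of the compounds shown here, two have been tested in a functional assay on MDA-MB-435 cells (Homo sapiens) for inhibition, read by sulforhodamine B assay, with a stated time of 48 h, tested at 10 uM; on this read-out lower numbers stand for less inhibition and higher numbers for more inhibition at the one concentration tested (going by the name of the read-out). Compound 1 gives 13% in this assay. Compound 2, the other measured compound, gives 7.38% in this assay; this is the lower of the two numbers, but the gap to compound 1 lies within the scatter, so the two values show no real difference.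

Compound 3, `c1ccc(Cn2cnc3ccc(-c4nc(-c5ccc6c(c5)ncn6C5CCCCC5)cn5ccnc45)cc32)cc1`, has not yet been measured. It differs from compound 2 in one place: benzyl in place of cyclohexyl on an aromatic nitrogen. For the measured compounds named here, no step between measured compounds of this kind is available, so the effect of this change is not known.

Both measured compounds sit at low inhibition, and compound 2 is estimated to carry that level into compound 3 with a step of a number 2.6 percentage points higher from compound 2 to compound 3 (within the scatter), none beyond the scatter. For compound 3 the expected value in this assay is 10%, with a range from 0% to 25%.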

Compound 3, a percentage reported as inhibition, at one concentration (the size of the read-out at that concentration, not a potency): -6.16%
Compound 3: the middle estimate sits 16.2 percentage points above what was measured; measured number below the stated range.
By their numbers in this assay, from the lowest: compound 3; then compounds 2 and 1 (each within the scatter of the next).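

The nitrogen that carries cyclohexyl in compound 2 is not a silent position in this assay: benzyl in place of cyclohexyl gives a number 13.5 percentage points lower from compound 2 to compound 3 (beyond the scatter) and is the only step beyond the scatter among these compounds. The change does not lift the low inhibition of compound 2 but takes it further down, with compound 3 at -6.16% on the far side of zero. No measurement among these compounds accounts for this step, so it stands as an observation without an explanation.

From the compounds shown here alone, what an amine or a carboxylic acid on the benzyl ring, or a longer chain such as phenethyl, would do on this nitrogen remains open. Also open, going by these compounds, is whether benzyl in place of cyclohexyl would shift the number of compound 1 in the same direction.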